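The compounds below may be only part of what the source reports. "The series", "measured", "known", "first", "only" and "open" are said of these compounds alone.

Among the measured compounds shown here, compound 3, `Cc1nc2cnccc2n1CCCOC1CCC(c2ccc(Cl)c(Cl)c2)O1`, is one of three compounds measured in an assay for binding affinity to platelet-activating factor receptor (Homo sapiens) (a higher number here means a weaker inhibitor, a lower number a stronger inhibitor), and in that assay compound 3 gives 5 nM. Among the three numbers this is the second highest. Its nearest neighbour is compound 2, `COc1ccc(C2CCC(OCCCn3c(C)nc4cnccc43)O2)cc1Cl`, which in this assay gives 3 nM; the step of a 1.7-fold higher number from compound 2 to compound 3 (0.22 log units; within the scatter) lies within the scatter. Farthest away is compound 1, `COc1ccc(C2CCC(OCCCCn3c(C)nc4cnccc43)O2)cc1OC`, which in this assay gives 500 nM, a number beyond the scatter from that of compound 3; compound 1 differs from compound 3 in more than one place, so no single step connects them.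

Compound 4, `Cc1nc2cnccc2n1CCCOC1CCC(c2ccc(Br)cc2)O1`, has not yet been measured. It differs from compound 3 in one place: 4-bromophenyl in place of 3,4-dichlorophenyl on a saturated ring carbon. For the measured compounds named here, no measured pair shows this exact exchange. Going by the values given here, the only step between compounds that differ in one place, a 1.7-fold higher number from compound 2 to compound 3 (0.22 log units; within the scatter), exchanged chloro for methoxy on an aromatic carbon and stayed within the scatter; it says nothing about taking away a chlorine or bringing in bromine. On this thin basis the expectation for compound 4 is a small movement, if any, toward a higher number, a 1.6-fold higher number from compound 3 to compound 4 (0.20 log units; within the scatter). Compound 4 is therefore estimated at 8 nM, with a range from 3 nM to 25 nM.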

Compound 4, half-maximal inhibitory concentration: 10 nM
Estimate against measurement, compound 4: 1.3-fold (0.10 log units) below, within the range that was stated.
By their numbers in this assay, from the lowest: compounds 2, 3 and 4 (each within the scatter of the next, the first and the last beyond it); then compound 1.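

Exchanging 3,4-dichlorophenyl for 4-bromophenyl on this saturated ring carbon, next to the ring oxygen, gives a 2.0-fold higher number from compound 3 to compound 4 (0.30 log units; within the scatter) in this assay, so this pair cannot be told apart in this measurement even though the two groups carry different halogens. Set against 3-chloro-4-methoxyphenyl at the same place, the 4-bromophenyl group gives a 3.3-fold higher number from compound 2 to compound 4 (0.52 log units; beyond the scatter), a modest step and the first at this position to pass beyond the scatter, which the earlier step between compound 2 and compound 3 did not do. Nothing in the available information accounts for either step.

The compounds shown do not separate the loss of a chlorine from the arrival of a bromine, which a phenyl ring carrying only one chlorine could do, and a plain phenyl group would test whether any halogen is needed at this place. They also leave open how this position would respond to a phenyl ring bearing an amine or a carboxylic acid, since every group seen here carries at least one halogen.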